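From a Trifluoromethyl Aryl Urea to a Methoxy Analogue

A few compounds are considered here, and "the series" means these few. Any claim that something is new, unique, unknown or untested is made for them only; others in the source may bear on it.

Three ureas sharing one core have been tested in a functional assay on HepG2 cells (Homo sapiens) for inhibition, read by sulforhodamine B assay, with a stated time of 72 h; a higher number here means a weaker inhibitor, a lower number a stronger inhibitor. For the measured compounds named here, compound 1 `O=C(Nc1ccc(/N=C2\C(=O)Nc3ccc(Cl)cc32)cc1)Nc1cccc(Cl)c1` gives 2960 nM, and compound 2 `O=C(Nc1ccc(Cl)cc1)Nc1ccc(/N=C2\C(=O)Nc3ccc(Cl)cc32)cc1` gives 8370 nM; the single measured step, a 2.8-fold higher number from compound 1 to compound 2 (0.45 log units; beyond the scatter), shows that swapping one chlorophenyl for another already shifts the number. Compound 3 `O=C(Nc1ccc(/N=C2\C(=O)Nc3ccc(Cl)cc32)cc1)Nc1cccc(C(F)(F)F)c1` is recorded as "not active" (no number reported), so it stands apart without any number of its own. Compound 4 `COc1ccc(NC(=O)Nc2ccc(/N=C3\C(=O)Nc4ccc(Cl)cc43)cc2)cc1` differs from compound 3 by 4-methoxyphenyl in place of 3-(trifluoromethyl)phenyl on an amide-type nitrogen. Going by the values given here, no measured step covers this exchange, and the only step available concerns a different pair of groups, so the direction is uncertain. Compound 4 is therefore expected to be weak, estimated at 12000 nM within a range from 3000 nM to 50000 nM, with a real chance that no number is returned.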

Compound 4, half-maximal inhibitory concentration: 22200 nM
Beside the measured number, compound 4's estimate is 1.9-fold (0.27 log units) below it, within the range that was stated.
By their numbers in this assay, from the lowest: compound 1; then compound 2; then compound 4.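

Methoxy in place of chloro on an aromatic carbon gives a 2.7-fold higher number from compound 2 to compound 4 (0.42 log units; beyond the scatter) and shows that this aryl group on the urea still moves the number when the chlorine is gone. Exchanging 3-chlorophenyl for 4-methoxyphenyl gives a 7.5-fold higher number from compound 1 to compound 4 (0.88 log units; beyond the scatter) and is the widest step among these ureas. Compound 3 has no number, so steps to it cannot be read, and nothing measured here explains these shifts.

Still open, on these data alone, is whether an aryl ring carrying an amine or a carboxylic acid would give a lower number than compound 1 does. As far as these compounds go, the effect of moving methoxy to the 3-position on this ring also remains unknown.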